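The source may report more compounds than this note shows. Statements on the series, on what has been measured and on what is new or still open speak of the compounds shown alone.

Compound 1 `COc1cc(C)nc2n/c(=N/C(=O)c3c(-c4ccc(Cl)cc4Cl)noc3C)sn12` is a fused two-ring core carrying a methoxy group. In a functional assay on the whole organism for inhibition, with Chenopodium ficifolium as the target, with a stated time of 72 h, tested at 100 mg/L (on this read-out higher numbers stand for more inhibition of growth at the one concentration tested and lower numbers for less inhibition of growth), compound 1 gives 80.4%. Compound 2 `COc1cc(OC)n2s/c(=N\C(=O)c3c(-c4ccc(Cl)cc4Cl)noc3C)nc2n1`, which carries a second methoxy group instead of the methyl, gives 82.7%, so the two numbers lie within the scatter of each other: a number 2.3 percentage points higher from compound 1 to compound 2 (within the scatter). Compound 3 `CSc1cc(C)nc2n/c(=N/C(=O)c3c(-c4ccc(Cl)cc4Cl)noc3C)sn12` differs from compound 1 by a change at one aromatic carbon: methylsulfanyl in place of methoxy on an aromatic carbon. Within the data shown here, no measured step exchanges methoxy for methylsulfanyl, and the only step known is small, so no shift beyond the scatter is expected, a number 1.4 percentage points lower from compound 1 to compound 3 (within the scatter). Compound 3 is expected to give about 79%, estimated between 60% and 93%.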

Compound 3, percent growth inhibition at one concentration: 75.2%
For compound 3 the middle estimate is 3.8 percentage points above the measured one, within the range that was stated.
By their numbers in this assay, from the lowest: compounds 3, 1 and 2 (each within the scatter of the next).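

In this assay, methylsulfanyl in place of methoxy on this aromatic carbon gives a number 5.2 percentage points lower from compound 1 to compound 3 (within the scatter). The earlier step changed the methyl group, whereas this one changes the methoxy group itself, and exchanging its oxygen for sulfur produces no shift beyond the scatter. No measurement is at hand that bears on this result. The compounds shown leave open whether a larger change at this carbon, such as an amine or a longer chain like butoxy, would move the growth inhibition beyond the scatter.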